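The source may hold more compounds than are shown below. What is called first, only, known or untested is meant among the compounds shown, and "the series" means these compounds.

Compound 2 `Cc1ccccc1-n1nc(C)c2c1NC(=O)[C@H](C)S[C@@H]2c1ccc(-c2ccoc2)cc1` in an assay on isolated protein for agonist activity at Bile acid receptor (Homo sapiens), read by AlphaScreen, with a stated time of 30 min (a lower number here means that less compound is needed, a higher number that more compound is needed for the effect), gives 3500 nM. Compound 1 `Cc1nn(-c2ccccc2C(C)C)c2c1[C@@H](c1ccc(Oc3ccccc3)cc1)S[C@@H](C)C(=O)N2` gives 1900 nM in this assay, and compound 3 `COc1ccccc1-n1nc(C)c2c1NC(=O)[C@H](C)S[C@@H]2c1ccc(Oc2ccccc2)cc1` gives 3300 nM; all three numbers sit within the scatter of one another, so compound 2 cannot be separated from either neighbour on these readings. Among the measured compounds shown here, the only single-site step on record, a 1.7-fold higher number from compound 1 to compound 3 (0.24 log units; within the scatter), concerns a substituent on the ring attached to the core and not the group carried at the far end of the pendant aryl, so it does not bear on the present change.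

Compound 4 `Cc1ccccc1-n1nc(C)c2c1NC(=O)[C@H](C)S[C@@H]2c1ccc(-c2cccc(C(=O)O)c2)cc1` differs from compound 2 by 3-carboxyphenyl in place of furan-3-yl on an aromatic carbon. For the measured compounds named here, no measured pair changes this position, so the series gives no direction for the step; the entering group is larger and brings a hydrogen-bond donor, which leaves room for a shift beyond the scatter in either sense. The estimate for compound 4 is 1800 nM in this assay, with a range of 400 nM to 8000 nM, corresponding to an expected step of a 1.9-fold lower number from compound 2 to compound 4 (0.29 log units; within the scatter).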

Compound 4, half-maximal effective concentration: "not active" (no number reported)
No number was reported for compound 4; there is nothing to compare the estimate with.
By their numbers in this assay, from the lowest: compounds 1, 3 and 2 (each within the scatter of the next).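

Among the compounds shown here, compound 4 is recorded as "not active" with no number, so no step from compound 2 to compound 4 can be read. The compounds shown leave open how groups at this place on the pendant aryl affect the number. No evidence on hand bears on this result.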